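Replacing the aromatic side group of compound 3

The source may report more compounds than this note shows. Statements on the series, on what has been measured and on what is new or still open speak of the compounds shown alone.

Measured in a functional assay on HepG2 cells (Homo sapiens) for inhibition, read by MTT assay, with a stated time of 48 h; a higher number here means a weaker inhibitor, a lower number a stronger inhibitor:
- compound 1 `CCOC(=O)C1=C(N/N=C(\c2ccc([N+](=O)[O-])cc2)N2CCN(c3ccc(F)cc3)CC2)Nc2[nH]nc(C)c2C1c1ccc(N(C)C)cc1`: 90200 nM
- compound 2 `CCOC(=O)C1=C(N/C=N/c2ncc(-c3ccccc3)s2)Nc2[nH]nc(C)c2C1c1ccc(N(C)C)cc1`: 9790 nM
- compound 3 `CCOC(=O)C1=C(N/N=C(/Br)c2ccccc2)Nc2[nH]nc(C)c2C1c1ccc(N(C)C)cc1`: 72000 nM

Compound 3, at 72000 nM, lies within the scatter of compound 1 and well above compound 2, which gives 9790 nM. The next compound, compound 4 `CCOC(=O)C1=C(N/N=C(/C(C)=O)C(=O)OCC)Nc2[nH]nc(C)c2C1c1ccc(N(C)C)cc1`, keeps the shared core and changes only the group on an amine nitrogen: a group of 10 heavy atoms (6 carbon, 1 nitrogen, 3 oxygen; no ring) in place of a group of 9 heavy atoms (7 carbon, 1 nitrogen, 1 bromine; one six-membered aromatic ring of carbon only), on an amine nitrogen. Among the measured compounds shown here, no pair of measured compounds differs in one place, so the data offer no direct guide to this change. Still, compound 2 at 9790 nM shows that another group on this nitrogen can come with a clearly lower number in this assay. A moderate move towards a lower number is therefore expected, close to the edge of the scatter, and the estimated step is a 2.4-fold lower number from compound 3 to compound 4 (0.38 log units; beyond the scatter). For compound 4 the estimated value is 30000 nM, with an expected range from 8000 nM to 100000 nM.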

Compound 4, half-maximal inhibitory concentration: > 100000 nM
Compound 4: only a limit was reported; the forecaster's own chance of this, stated with the estimate: 10%; at least 3.3-fold (0.52 log units) between middle value and limit.
By their numbers in this assay, from the lowest: compound 2; then compounds 3 and 1 (each within the scatter of the next). At a limit, above all of these: compound 4.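

On an amine nitrogen whose other neighbours are a double-bonded ring carbon, the group of 10 heavy atoms with no ring, in place of the group of 9 heavy atoms with one six-membered aromatic ring of carbon only, gives in this assay an at least 1.3-fold higher number from compound 3 to compound 4 (0.14 log units; that floor lies within the scatter). Among the compounds shown here, this is the first step at this position that can be read, and it shows that this ring-free group brings no move towards a lower number, although its floor does not establish a real rise. The reading for compound 4 is a limit and not a number: the limit of > 100000 nM in this assay, at which 1 of the 4 values shown sits.

On these data alone, how far compound 4 actually lies from compound 3 stays open. So does how this position would respond to a ring-free chain carrying an amine or a carboxylic acid, or to a methoxy group on the aromatic ring of compound 3.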